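Returning from an amide piperazine to a hydroxypiperidine chain

This account rests on a few compounds, and the source may have more. Where it says the series, first, only, none or still open, it means among the compounds named here.

Measured compounds:
compound 1 `CCc1nn2c(C)cc(C)nc2c1Cc1ccc(CCC(O)C2CCNCC2)cc1` – 24 nM
compound 2 `CCc1nn2c(C)cc(C)nc2c1Cc1ccc(CCC(=O)N2CCNCC2)cc1` – 53 nM

Both were tested in a functional assay on HeLa cells for antagonist activity at G-prodeshotein coupled receptor 4 (Homo sapiens), read by HTRF and cAMP accumulation, with a stated time of 15 min; on this read-out higher numbers stand for weaker inhibition and lower numbers for stronger inhibition. Within the data shown here, of the two numbers, compound 2 has the higher one; the only step measured so far, a 2.2-fold higher number from compound 1 to compound 2 (0.34 log units; beyond the scatter), records that change as modest but beyond the usual scatter.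

Compound 3 `CCc1nn2c(C)cc(C)nc2c1Cc1ccc(CCCC2(O)CCN(C(C)C)CC2)cc1` differs from compound 2 in one place: (4-hydroxy-1-isopropylpiperidin-4-yl)methyl in place of (piperazin-1-yl)carbonyl on a saturated chain carbon, two bonds along the chain from an aromatic carbon. The step that bears on this change is a 2.2-fold higher number from compound 1 to compound 2 (0.34 log units; beyond the scatter), since it describes the reverse kind of move, from a chain carrying a hydroxy group and a piperidine to the amide-linked piperazine. Compound 3 restores a chain with a hydroxy group and a piperidine, which makes it resemble compound 1 more than compound 2, so the number is expected to fall back rather than rise further. The step expected is a 2.1-fold lower number from compound 2 to compound 3 (0.33 log units; beyond the scatter), a modest decrease of about the size seen before, in the opposite direction. For compound 3 the estimated value in this assay is 25 nM, with a likely range from 8 nM to 80 nM.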

Compound 3, half-maximal inhibitory concentration: 63 nM
Compound 3: the middle estimate sits 2.5-fold (0.40 log units) below what was measured, within the range that was stated.
By their numbers in this assay, from the lowest: compound 1; then compounds 2 and 3 (each within the scatter of the next).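

In this assay the record gives a 1.2-fold higher number from compound 2 to compound 3 (0.08 log units; within the scatter) and so places the (4-hydroxy-1-isopropylpiperidin-4-yl)methyl group and the (piperazin-1-yl)carbonyl group level on this saturated chain carbon, even though the entering group has more heavy atoms and one fewer nitrogen. The chains of compound 1 and compound 3 both carry a hydroxy group and a piperidine, yet the data show a 2.6-fold higher number from compound 1 to compound 3 (0.42 log units; beyond the scatter) and so those two features alone do not give the number of compound 1. No measurement offered here explains either step.

The groups in compound 1 and compound 3 differ both in the isopropyl on the ring nitrogen and in where the hydroxy group is attached, so the compounds shown cannot tell which of these differences accounts for the gap. As far as these compounds go, it remains open whether a 4-hydroxypiperidin-4-yl group with no isopropyl, or one with a methyl or cyclopropyl group in its place, would read closer to compound 1, and how a simple primary amine or a carboxylic acid would read at this position.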